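This account rests on a few compounds, and the source may have more. Where it says the series, first, only, none or still open, it means among the compounds named here.

Measured in a functional assay on C6 cells (Rattus norvegicus) for cytotoxicity, read by CellTiter-Glo, with a stated time of 72 h; on this read-out higher numbers stand for weaker inhibition and lower numbers for stronger inhibition:
- compound 1 `C=C1C(=O)C2=C3[C@H]1[C@H]1OC(=O)C(CO)=C1CC[C@]3(O)CC[C@]21C(=O)C[C@H]2C(=C)CC[C@H]3C(=C)C(=O)O[C@@H]3[C@H]21`: 9900 nM
- compound 2 `C=C1C(=O)C2=C3[C@H]1[C@H]1OC(=O)C(=C)[C@@H]1CC[C@@]3(O)CC[C@]21C(=O)C[C@H]2C(=C)CC[C@H]3C(=C)C(=O)O[C@@H]3[C@H]21`: > 10000 nM
- compound 3 `C=C1C(=O)O[C@@H]2[C@@H]3C4=C(C(=O)[C@H]3CO)[C@]3(CC[C@]4(O)CC[C@@H]12)C(=O)C[C@H]1C(=C)CC[C@H]2C(=C)C(=O)O[C@@H]2[C@H]13`: > 10000 nM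

Of the compounds shown here, three have been read in this assay. Within the data shown here, compound 1 is the only one that returns a number, with compound 1 giving 9900 nM. Compound 2 returns a limit of the assay rather than a number, compound 2 giving > 10000 nM. Compound 3 likewise returns only a limit, compound 3 giving > 10000 nM. Compound 2 therefore stands at the limit of > 10000 nM in this assay, at which 2 of the 3 values shown sit, and nothing further can be said of its position relative to compound 3; the number for compound 1 lies close to that limit as well. Among the measured compounds shown here, no step between measured compounds that differ in one place is available, so no measured step can be drawn on.

The next compound, compound 4 `C=C1C(=O)C2=C3[C@H]1[C@H]1OC(=O)C(=C)[C@@H]1CC[C@]3(O)CC[C@]21C(=O)C[C@H]2C(=C)CC[C@H]3C(=C)C(=O)O[C@@H]3[C@H]21`, is the stereoisomer of compound 2: the two compounds have the same atoms and bonds and differ only in configuration as drawn: 1 of 9 stereo elements differ; a stereocentre at a saturated ring carbon is drawn R in compound 2 and S in compound 4. For the measured compounds named here, with compound 2 itself at the limit and no step measured, no shift beyond the usual scatter is expected in this assay; the step of a number no higher from compound 2 to compound 4 (the limit leaves the size open) is an estimate only. Compound 4 is expected to give about 10000 nM, within 5000 nM to 20000 nM, with a good chance that the assay again reports only a limit.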

Compound 4, half-maximal inhibitory concentration: 1200 nM
Compound 4: the middle estimate sits 8.3-fold (0.92 log units) above what was measured; measured number outside the range, below it.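

Compound 2 gives > 10000 nM in this assay, and this is a limit of the assay, not a number. Among these compounds, the change drawn R in compound 2 and S in compound 4, at a stereocentre on a saturated ring carbon, gives an at least 8.3-fold lower number from compound 2 to compound 4 (0.92 log units; beyond the scatter); this is the first step read, it lies beyond the scatter, and the limit leaves its full size open. On this read-out the lower number stands for stronger inhibition, and the shift can be placed on this single stereocentre alone, because no group leaves or enters: the fact that compounds 2 and 4 differ only in the configuration as drawn.

Among the compounds shown here, this one pair is the only reading of the stereocentre, so no rule for the wider series follows from it. Open too, from the compounds shown here alone, is whether the lower number of compound 4 persists when the core of compound 4 carries a further group, such as an amine or a carboxylic acid.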